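A few compounds are considered here, and "the series" means these few. Any claim that something is new, unique, unknown or untested is made for them only; others in the source may bear on it.

Working notes on the series.

Compound 1 `Nc1nc2ccc(-c3cn([C@@H]4CN[C@H](C(=O)Nc5ccc(Br)cc5)C4)nn3)nc2s1` is the parent. In a functional assay on K562 cells (Homo sapiens) for inhibition, read by MTT assay, with a stated time of 48 h (a lower number here means a stronger inhibitor, a higher number a weaker inhibitor), compound 1 gives 24400 nM. Compound 2 `CC(=O)Nc1nc2ccc(-c3cn([C@@H]4CN[C@H](C(=O)Nc5ccc(Br)cc5)C4)nn3)nc2s1` differs from it by acetyl in place of hydrogen on a nitrogen on an aromatic ring and gives 5020 nM in this assay; the step is a 4.9-fold lower number from compound 1 to compound 2 (0.69 log units; beyond the scatter). Compound 3 `Nc1nc2ccc(-c3cn([C@@H]4CN[C@H](C(=O)Nc5ccc(F)c(F)c5)C4)nn3)nc2s1` carries a different amide-side ring, (3,4-difluorophenyl in place of 4-bromophenyl on an amide-type nitrogen), and gives 33200 nM in this assay; the step is a 1.4-fold higher number from compound 1 to compound 3 (0.13 log units; within the scatter), so compound 1 and compound 3 cannot be ordered against each other.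

Compound 4 `CC(=O)Nc1nc2ccc(-c3cn([C@@H]4CN[C@H](C(=O)Nc5ccc(F)c(F)c5)C4)nn3)nc2s1` is not yet measured. It stands to compound 3 as compound 2 stands to compound 1: the change is acetyl in place of hydrogen on a nitrogen on an aromatic ring, and the place of the change is described in the same words for both pairs, so it is the same change. The two cores differ by 3,4-difluorophenyl in place of 4-bromophenyl on an amide-type nitrogen.

For the measured compounds named here, only one measured instance of this change exists, so the expectation rests on a single step. The step from compound 3 to compound 4 is expected to be a 4.4-fold lower number from compound 3 to compound 4 (0.65 log units; beyond the scatter) in this assay, matching a 4.9-fold lower number from compound 1 to compound 2 (0.69 log units; beyond the scatter), because compound 3 with 33200 nM and compound 1 with 24400 nM sit within the scatter of each other. Compound 4 is therefore estimated at 7500 nM in this assay, with a range of 3000 nM to 18000 nM.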

Compound 4, half-maximal inhibitory concentration: 63000 nM
Beside the measured number, compound 4's estimate is 8.4-fold (0.92 log units) below it; measured number outside the range, above it.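

In this assay, acetyl in place of hydrogen on a nitrogen on an aromatic ring does not carry from the core of compound 1 to the core of compound 3, where it gives a 1.9-fold higher number from compound 3 to compound 4 (0.28 log units; within the scatter), and the two steps disagree: the same change on two cores in this assay, a 4.9-fold lower number (0.69 log units; beyond the scatter) from compound 1 to compound 2 and a 1.9-fold higher number (0.28 log units; within the scatter) from compound 3 to compound 4, 9.2-fold (0.96 log units) apart, beyond the scatter of two such steps

Read the other way, 3,4-difluorophenyl in place of 4-bromophenyl also depends on the partner group, giving a 13-fold higher number from compound 2 to compound 4 (1.10 log units; beyond the scatter) with acetyl present, against a step within the scatter without it: the same change on two cores in this assay, a 1.4-fold higher number (0.13 log units; within the scatter) from compound 1 to compound 3 and a 13-fold higher number (1.10 log units; beyond the scatter) from compound 2 to compound 4, 9.2-fold (0.96 log units) apart, beyond the scatter of two such steps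

The two changes are therefore not independent in these four compounds, but a single set of four in one cell assay does not show why, nor whether the acetyl step follows the amide-side ring in general.

From the compounds shown here alone, it remains open how the acetyl step behaves with other amide-side rings, such as an unsubstituted phenyl ring. Going by these compounds, it also remains open whether a longer acyl chain in place of acetyl would follow compound 2 or compound 4.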